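Swapping a hydroxyethyl for a cyclohexyl on two related cores

The source may hold more compounds than are shown below. What is called first, only, known or untested is meant among the compounds shown, and "the series" means these compounds.

Compound 1 `COc1ccc2nc(NCCO)c(S(C)(=O)=O)nc2c1` and compound 3 `COc1ccc2nc(S(C)(=O)=O)c(NCCO)nc2c1` are built from the same atoms joined differently; how their cores differ is not broken down here. In an ADME assay on HepG2 cells (Homo sapiens) for cytotoxicity, read by CellTiter-Glo, with a stated time of 48 h (a lower number here means that less compound is tolerated, a higher number that more compound is tolerated), compound 1 gives 39800 nM. Compound 3 reaches only the assay limit in this assay, at > 100000 nM, the limit described as the limit of > 100000 nM in this assay, at which 1 of the 3 values shown sits. Compound 2 `COc1ccc2nc(NC3CCCCC3)c(S(C)(=O)=O)nc2c1` carries the change (cyclohexyl in place of 2-hydroxyethyl on a nitrogen on an aromatic ring). In this assay compound 2 gives 12600 nM, and this assay records a 3.2-fold lower number from compound 1 to compound 2 (0.50 log units; beyond the scatter). Compound 4 `COc1ccc2nc(S(C)(=O)=O)c(NC3CCCCC3)nc2c1` carries the same change on the core of compound 3, (cyclohexyl in place of 2-hydroxyethyl on a nitrogen on an aromatic ring). The step expected from compound 3 to compound 4 in this assay is an at least 2.5-fold lower number from compound 3 to compound 4 (0.39 log units; beyond the scatter), resting on the step already seen from compound 1 to compound 2 and on the limit recorded for compound 3. Compound 4 is therefore estimated at 40000 nM, between 12000 nM and 120000 nM.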

Compound 4, half-maximal cytotoxic concentration: 79400 nM
For compound 4 the middle estimate is 2.0-fold (0.30 log units) below the measured one; low and high end bracket the measured number.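

In this assay, cyclohexyl in place of 2-hydroxyethyl on a nitrogen on an aromatic ring gives an at least 1.2-fold lower number from compound 3 to compound 4 (0.10 log units; that floor lies within the scatter), the same direction as on the core of compound 1, although this floor is not by itself beyond the scatter. Compound 3 stands at a limit of the assay, not at a number: the limit of > 100000 nM in this assay, at which 1 of the 4 values shown sits. The series therefore shows the direction of the change on both cores but does not show that its size carries over from one core to the other: the same change on two cores in this assay, a 3.2-fold lower number (0.50 log units; beyond the scatter) from compound 1 to compound 2 and an at least 1.2-fold lower number (0.10 log units; that floor lies within the scatter) from compound 3 to compound 4; the limit leaves it open whether they differ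

The compounds shown leave open whether the step belongs to the cyclohexyl ring or to the loss of the 2-hydroxyethyl group. A plain ethyl chain or a cyclopentyl on that nitrogen, on both cores, would bear on this.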